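The source may hold more compounds than are shown below. What is called first, only, known or untested is meant among the compounds shown, and "the series" means these compounds.

Measured so far in a functional assay on Ehrlich cells (Mus musculus) for cytotoxicity, tested at 100 ug/mL; a lower number here means a weaker effect, a higher number a stronger effect of the compound at the concentration tested:

- compound 1 `COc1ccc(C2C(C#N)=C(N)N(c3cc(OC)c(OC)c(OC)c3)C3=C2C(=O)CC(C)(C)C3)cc1`: 15%
- compound 2 `COc1cc(N2C(N)=C(C#N)C(/C=C/c3ccccc3)C3=C2CC(C)(C)CC3=O)cc(OC)c1OC`: 40%
- compound 3 `COc1cc(N2C(N)=C(C#N)C(c3ccc(OC)c4ccccc34)C3=C2CC(C)(C)CC3=O)cc(OC)c1OC`: 40%

Compound 3 stands level with compound 2 at the digits printed, the two of them together at the top of the three numbers in this assay; the step of no change at the digits printed from compound 2 to compound 3 (within the scatter) lies within the scatter, while compound 1 sits furthest away, the step of a number 25 percentage points higher from compound 1 to compound 3 (beyond the scatter) being beyond the scatter. Compound 4 `COc1cc(N2C(N)=C(C#N)C(c3ccc(Cl)cc3Cl)C3=C2CC(C)(C)CC3=O)cc(OC)c1OC` is not yet measured. The change from compound 3 is 2,4-dichlorophenyl in place of 4-methoxynaphthalen-1-yl on a saturated ring carbon. Within the data shown here, two measured steps touch the same saturated ring carbon: a number 25 percentage points higher from compound 1 to compound 2 (beyond the scatter) and a number 25 percentage points higher from compound 1 to compound 3 (beyond the scatter), each a modest rise, both away from the 4-methoxyphenyl group; the one step between two non-methoxyphenyl groups, no change at the digits printed from compound 2 to compound 3 (within the scatter), shows no change. Nothing measured here swaps in a 2,4-dichlorophenyl group, so no step beyond the scatter is expected in this assay, and the expected step is no change at the digits printed from compound 3 to compound 4 (within the scatter). Compound 4 is therefore estimated at 40%, within 25% to 55%.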

Compound 4, a percentage reported as activity, at one concentration (the size of the read-out at that concentration, not a potency): 100%
Compound 4: the middle estimate sits 60 percentage points below what was measured, and the stated range ends below it.
By their numbers in this assay, from the lowest: compound 1; then compounds 2 and 3 (each within the scatter of the next); then compound 4.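

In this assay, the 2,4-dichlorophenyl group on this saturated ring carbon gives a number 60 percentage points higher from compound 3 to compound 4 (beyond the scatter), a number 60 percentage points higher from compound 2 to compound 4 (beyond the scatter) and a number 85 percentage points higher from compound 1 to compound 4 (beyond the scatter), all large steps, so this position can separate the compounds far more widely than the earlier groups showed. Neither a single aromatic ring nor a lack of oxygen in the group is enough on its own: compound 1 also carries one six-membered aromatic ring and gives 15%, while compound 2 also has no oxygen in this group and gives 40%. No measurement shown here accounts for the rise.

On these data alone, it remains open whether both chlorine atoms are needed, as a 4-chlorophenyl or 2-chlorophenyl group would show, or whether a 2,4-difluorophenyl or 2,4-dimethylphenyl group would serve equally. As far as these compounds go, with a read-out at a single concentration, the potency of compound 4 also remains open.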